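A few compounds are considered here, and "the series" means these few. Any claim that something is new, unique, unknown or untested is made for them only; others in the source may bear on it.

Measured so far:
compound 1, `CNCc1cc(-c2cccnc2F)n(S(=O)(=O)c2cccnc2)c1`, -0.85
compound 2, `CNCc1cn(S(=O)(=O)c2ccoc2)c(-c2cccnc2F)c1F`, 0.45

Both compounds were read in a physicochemical assay for lipophilicity, read by HPLC, at pH 7.4; a higher number here means a more lipophilic compound, a lower number a more polar compound. Compound 2 stands highest of the two numbers; its nearest neighbour, compound 1, lies lower by a gap that is beyond the usual scatter. Going by the values given here, the two measured compounds differ in more than one place, so no single step between them is known, and their values show only where each one stands.

Compound 3, `CNCc1cn(S(=O)(=O)c2cccnc2Cl)c(-c2cccnc2F)c1F`, has not yet been measured in this assay. It differs from compound 2 in one place: 2-chloropyridin-3-yl in place of furan-3-yl on a sulfonyl sulfur. Among the compounds with values here, no measured step of this kind is available, so the expected step is a modest rise, a number 0.30 log units higher from compound 2 to compound 3 (within the scatter), with a result within the scatter also quite possible. Compound 3 is therefore expected to give 0.75 in this assay, within a range from 0.2 to 1.3.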

Compound 3, distribution coefficient: 0.75
Estimate against measurement, compound 3: no gap at the digits printed, within the range that was stated.
By their numbers in this assay, from the lowest: compound 1; then compounds 2 and 3 (each within the scatter of the next).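

Going by these compounds alone, this is the first one-place comparison in the set: on a sulfonyl sulfur whose other neighbour is an aromatic nitrogen, putting 2-chloropyridin-3-yl in place of furan-3-yl gives a number 0.30 log units higher from compound 2 to compound 3 (within the scatter) in this assay, so this measurement does not separate the two compounds. The exchange is a sizeable one on paper, with a five-membered aromatic ring giving way to a six-membered aromatic ring that carries chlorine, yet here it leaves the reading within the usual scatter. Nothing available explains this result.

As far as these compounds go, it remains open what the chlorine contributes on this core, since the pair changes the whole ring at once. Also open, from the compounds shown here alone, is whether a group of another kind at this place, such as a carboxylic acid or a longer alkyl chain, would give a step beyond the scatter.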